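The source may report more compounds than this note shows. Statements on the series, on what has been measured and on what is new or still open speak of the compounds shown alone.

Measured so far in a functional assay on RS4-11 cells (Homo sapiens) for inhibition, read by CCK-8 assay, with a stated time of 48 h, tested at 20 uM; a lower number here means less inhibition of growth, a higher number more inhibition of growth at the concentration tested:
compound 1 `Cc1ccc(S(=O)(=O)Oc2ccccc2/C=C(\C#N)C(=O)Nc2nnc(Cc3ccc(F)cc3)s2)cc1`: 72%
compound 2 `N#C/C(=C\c1ccccc1OS(=O)(=O)c1ccc([N+](=O)[O-])cc1)C(=O)Nc1nnc(Cc2ccc(F)cc2)s1`: 55%
compound 3 `N#C/C(=C\c1ccccc1OS(=O)(=O)c1ccc(Cl)cc1)C(=O)Nc1nnc(Cc2ccc(F)cc2)s1`: 68%

Compound 3, at 68%, cannot be told apart from its nearest neighbour: a number 4 percentage points lower from compound 1 to compound 3 (within the scatter). The gap to the remaining compound is real: a number 13 percentage points higher from compound 2 to compound 3 (beyond the scatter).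

The next compound is compound 4 `N#C/C(=C\c1ccccc1OS(=O)(=O)c1ccc(Cl)cc1)C(=O)Nc1nnc(Cc2ccc(Cl)cc2)s1`, which differs from compound 3 in a single substituent: chloro in place of fluoro on an aromatic carbon. In other words, 4-fluorobenzyl becomes 4-chlorobenzyl, with the swap on an aromatic carbon para to a large group.

Going by the values given here, no measured pair tests this spot, since all three measured compounds carry the 4-fluorobenzyl group and differ only elsewhere in the molecule. Those steps are therefore a loose guide to how far a single substituent swap can move this read-out. The larger ones are modest, such as a number 17 percentage points lower from compound 1 to compound 2 (beyond the scatter), while the swap of chloro for methyl stayed within the scatter. With nothing in the data to set a direction, a swap of one halogen for another is not expected to move the number beyond the scatter. The expected step is a number 1 percentage points higher from compound 3 to compound 4 (within the scatter). For compound 4 the estimate is 69%, with an expected range from 56% to 82%.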

Compound 4, percent growth inhibition at one concentration: 64%
Compound 4: middle estimate off by 5 percentage points, on the high side; the range from low to high includes it.
By their numbers in this assay, from the lowest: compounds 2, 4, 3 and 1 (each within the scatter of the next, the first and the last beyond it).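

Going by these compounds alone, this is the first compound to change the 4-fluorobenzyl group, and in this assay the swap to 4-chlorobenzyl gives a number 4 percentage points lower from compound 3 to compound 4 (within the scatter), so the two compounds cannot be told apart. The earlier steps shown here all changed the substituent at the other end of the molecule, where nitro in place of methyl gave a number 17 percentage points lower from compound 1 to compound 2 (beyond the scatter), so the new result adds a second site and shows that growth inhibition at this single concentration holds up with either halogen on the benzyl ring. Nothing available bears on why this swap leaves the read-out within the scatter.

Fluoro and chloro are the only groups shown at this place, so it remains open whether a methoxy group, an amine or a carboxylic acid on the same aromatic carbon would keep the number or move it beyond the scatter. A reading at one concentration also leaves open whether compound 3 and compound 4 would still match across a full range of concentrations, where a difference too small to see here might appear.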